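Swapping an indole for a hydroxy-methoxyphenyl group

The source may hold more compounds than are shown below. What is called first, only, known or untested is meant among the compounds shown, and "the series" means these compounds.

Measured so far:
compound 1 `COc1cc(-c2c(-c3ccc4cc[nH]c4c3)c(=O)c2=O)cc(OC)c1OC` gives 6.6 nM
compound 2 `COc1ccc(-c2c(-c3c(OC)cc(OC)cc3OC)c(=O)c2=O)cc1` gives 850 nM
compound 3 `COc1ccc(-c2c(-c3cc(OC)c(OC)c(OC)c3)c(=O)c2=O)cc1N` gives 1.4 nM

In a functional assay on CCRF-CEM cells (Homo sapiens) for inhibition, read by MTT assay, with a stated time of 72 h (a lower number here means a stronger inhibitor, a higher number a weaker inhibitor), compound 1 holds the middle place of the three numbers, below compound 2 and above compound 3. Compound 4 `COc1ccc(-c2c(-c3cc(OC)c(OC)c(OC)c3)c(=O)c2=O)cc1O` carries one change from it: 3-hydroxy-4-methoxyphenyl in place of 1H-indol-6-yl on an aromatic carbon, with 3-hydroxy-4-methoxyphenyl in place of 1H-indol-6-yl on an aromatic carbon.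

Among the measured compounds shown here, only one measured step bears directly on this swap. It is a 4.7-fold lower number from compound 1 to compound 3 (0.67 log units; beyond the scatter), where 3-amino-4-methoxyphenyl replaces the same 1H-indol-6-yl. That group differs by name from the incoming one only in having amino instead of hydroxy. Compound 2 differs from compound 1 in more than one place, so it offers no clean comparison. A similar modest drop in this assay is therefore expected, although amino and hydroxy need not behave alike. The expected change is a 2.6-fold lower number from compound 1 to compound 4 (0.42 log units; beyond the scatter) and its size is only an estimate. For compound 4 the estimated value is 2.5 nM with an expected range from 0.7 nM to 10 nM as the likely span.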

Compound 4, half-maximal inhibitory concentration: 1.7 nM
Compound 4: the middle estimate sits 1.5-fold (0.17 log units) above what was measured; the range from low to high includes it.
By their numbers in this assay, from the lowest: compounds 3 and 4 (each within the scatter of the next); then compound 1; then compound 2.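

In this assay, 3-hydroxy-4-methoxyphenyl also improves on 1H-indol-6-yl (a 3.9-fold lower number from compound 1 to compound 4 (0.59 log units; beyond the scatter)), so the gain at this place on the four-membered aromatic ring is no longer tied to the amino compound alone. Hydroxy in place of amino (a 1.2-fold higher number from compound 3 to compound 4 (0.08 log units; within the scatter)) gives two numbers that this assay cannot tell apart, so on the shared core these two groups serve equally well here. Nothing measured on these compounds explains that match.

Still open, as far as these compounds go, is whether the number stays this low with a fluorine atom, a methyl group or a carboxylic acid in place of the hydroxy. Compound 2 differs from compound 4 in more than one place, so it cannot show whether the hydroxy or amino group is needed at all.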